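Lengthening the Ether Chain from Compound 2 to Compound 3

This account rests on a few compounds, and the source may have more. Where it says the series, first, only, none or still open, it means among the compounds named here.

Compound 2 `C=CCOc1cccc(/C=N/n2c(-c3ccccc3)nc3ccccc3c2=O)c1` carries an allyloxy group on the shared core. For the measured compounds named here, in a functional assay on the whole organism (strain albino CF-1) with Mus musculus as the target, in the maximal electroshock model, with a stated time of 0.5 h (on this read-out higher numbers stand for an effect only at larger amounts of compound and lower numbers for an effect already at smaller amounts), compound 2 gives 300 mg/kg, the higher of the two numbers measured so far; its nearest neighbour is compound 1 `CCCOc1cccc(/C=N/n2c(-c3ccccc3)nc3ccccc3c2=O)c1`, which in this assay gives 100 mg/kg. Going by the values given here, the one measured step, a 3.0-fold higher number from compound 1 to compound 2 (0.48 log units; beyond the scatter), exchanges a saturated tail for an unsaturated one. Compound 3 `C=CCCOc1cccc(/C=N/n2c(-c3ccccc3)nc3ccccc3c2=O)c1` differs from compound 2 by allyl in place of vinyl on a saturated chain carbon bound to an oxygen on an aromatic ring. Among the compounds with values here, no measured step shows the chain being lengthened, so for compound 3 the expected shift is no change at the digits printed from compound 2 to compound 3 (within the scatter), nothing beyond the scatter. Compound 3 is therefore estimated at 300 mg/kg, between 100 mg/kg and 1000 mg/kg.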

Compound 3, minimum effective dose: 300 mg/kg
Estimate against measurement, compound 3: no gap at the digits printed; measured number inside the range.
By their numbers in this assay, from the lowest: compound 1; then compounds 2 and 3 (each within the scatter of the next).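

In this assay the change from allyloxy to (but-3-en-1-yl)oxy gives no change at the digits printed from compound 2 to compound 3 (within the scatter) and so this extra chain carbon leaves the number unmoved. The tail of compound 3 also ends in a double bond and shows a 3.0-fold higher number from compound 1 to compound 3 (0.48 log units; beyond the scatter) so both unsaturated tails stand apart from the saturated tail of compound 1 by the same margin. Nothing available here gives a reason for these numbers.

As far as these compounds go, whether a saturated butoxy chain would read like compound 1 or like compound 3 stays open, and that comparison would separate chain length from the double bond. From the compounds shown here alone, an amine at the end of the chain is also open.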